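The source may hold more compounds than are shown below. What is called first, only, known or untested is meant among the compounds shown, and "the series" means these compounds.

Measured so far, in a functional assay for inhibition, read by Griess assay, with a stated time of 150 min, tested at 1 mM; a lower number here means less inhibition, a higher number more inhibition at the concentration tested (going by the name of the read-out):

Compound 1, `N#C/C(=C\C=C(/Cl)c1ccc(Br)cc1)C(=O)c1c[nH]c2ccccc12`, gives 76.7%.
Compound 2, `COc1ccc(/C(Cl)=C/C=C(\C#N)C(=O)c2c[nH]c3ccccc23)cc1OC`, gives 75%.
Compound 3, `COc1ccc(/C(Cl)=C/C=C(\C#N)C(=O)c2c(C)[nH]c3ccccc23)cc1OC`, gives 75.8%.

The three numbers sit close together. Compound 3 is compound 2 with one change, (methyl in place of hydrogen on an aromatic carbon), and the step it made in this assay is a number 0.8 percentage points higher from compound 2 to compound 3 (within the scatter). The two values cannot be put in any order by this measurement alone.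

Compound 1 has a different core from compound 2; the difference between the two cores is not broken down here. Compared with compound 3, compound 1 is a number only slightly higher, again within the scatter, and compared with compound 2 the gap is also within the scatter. So among these three, no compound's number in this assay can be called higher or lower than another's.

Compound 4, `Cc1[nH]c2ccccc2c1C(=O)/C(C#N)=C/C=C(\Cl)c1ccc(Br)cc1`, has not yet been measured. It relates to compound 1 exactly as compound 3 relates to compound 2: methyl in place of hydrogen on an aromatic carbon. The place description is the same word for word in both pairs, so this is the same change on a different core.

Because the step of a number 0.8 percentage points higher from compound 2 to compound 3 (within the scatter) was within the scatter, the step from compound 1 to compound 4 is expected to be small as well, about a number 0.3 percentage points higher from compound 1 to compound 4 (within the scatter). On that basis compound 4 is estimated at 77% in this assay, with a likely range from 69% to 85%.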

Compound 4, a percentage reported as inhibition, at one concentration (the size of the read-out at that concentration, not a potency): 78.3%
Compound 4: the middle estimate sits 1.3 percentage points below what was measured; the measured number falls inside the stated range.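

In this assay, methyl in place of hydrogen on an aromatic carbon of the core of compound 1 gives a step of a number 1.6 percentage points higher from compound 1 to compound 4 (within the scatter). Set beside the same change on the other core, this step cannot be told apart from the earlier one: the same change on two cores in this assay, a number 0.8 percentage points higher (within the scatter) from compound 2 to compound 3 and a number 1.6 percentage points higher (within the scatter) from compound 1 to compound 4, 0.8 percentage points apart, within the scatter of two such steps. This shows that, in this one assay, the change behaves alike on these two cores, so the earlier step was a fair guide to the new one, but it does not show that methyl has any real effect on either core, since neither step rises above the scatter, and two pairs of compounds cannot establish a rule for other cores or other assays.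

The compounds shown leave open what happens when something other than methyl stands at this place, next to the ring nitrogen and next to the ring atom that bears a large group, such as a longer chain, an amine or a carboxylic acid. They also leave open whether a step too small to see here would appear at other concentrations, since each number is a single reading at one concentration and not a potency.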